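A few compounds are considered here, and "the series" means these few. Any claim that something is new, unique, unknown or untested is made for them only; others in the source may bear on it.

Measured so far:
- compound 1, `CC(C)c1cccc(C(C)C)c1OC(=O)NC(=O)OCCCc1ccccc1`: 660 nM
- compound 2, `CCCCCCCCCCCCOC(=O)NC(=O)Oc1c(C(C)C)cccc1C(C)C`: 21 nM

Both compounds were tested in an assay on microsomes from intestine for inhibition of acyl-CoA:cholesterol acyltransferase (Oryctolagus cuniculus); on this read-out higher numbers stand for weaker inhibition and lower numbers for stronger inhibition. For the measured compounds named here, compound 1 gives the higher of the two numbers; the only other measured compound is compound 2, and the step of a 31-fold lower number from compound 1 to compound 2 (1.50 log units; beyond the scatter) shows a saturated chain extended in place of a phenyl ring strengthened inhibition markedly.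

Compound 3, `CCCCC(C)(C)OC(=O)NC(=O)Oc1c(C(C)C)cccc1C(C)C`, is not yet measured. It differs from compound 1 in one place: 1,1-dimethylpentyl in place of 3-phenylpropyl on an oxygen next to a carbonyl group. Going by the values given here, the single known step bears on this change only loosely: it replaced a ring by a long saturated chain, whereas compound 3 carries a shorter, branched saturated chain and also loses the ring. Because the step of a 31-fold lower number from compound 1 to compound 2 (1.50 log units; beyond the scatter) points toward stronger inhibition when the ring is gone, a modest gain is expected rather than a loss, though smaller than in compound 2. Compound 3 is therefore estimated at 300 nM (range 80 nM to 1500 nM), an expected step of a 2.2-fold lower number from compound 1 to compound 3 (0.34 log units; beyond the scatter).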

Compound 3, half-maximal inhibitory concentration: 64 nM
For compound 3 the middle estimate is 4.7-fold (0.67 log units) above the measured one, and the stated range ends above it.
By their numbers in this assay, from the lowest: compound 2; then compound 3; then compound 1.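

In this assay, the change from 3-phenylpropyl to 1,1-dimethylpentyl gives a 10-fold lower number from compound 1 to compound 3 (1.01 log units; beyond the scatter), so a second ring-free group on this oxygen also comes with a large drop in the number. The gain therefore does not depend on the long straight chain of compound 2: a branched group carrying its two methyl groups on the carbon attached to the oxygen also fits this trend, and no compound shown goes against it. No measurement here explains why these ring-free groups give stronger inhibition.

The compounds shown do not separate the loss of the aromatic ring from the branching, so a straight heptyl chain and a 3-cyclohexylpropyl group remain open comparisons. An amine or a carboxylic acid at the end of the chain is also untested territory here.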